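Swapping an aryl urea for a saturated ring

The source may report more compounds than this note shows. Statements on the series, on what has been measured and on what is new or still open speak of the compounds shown alone.

Compound 1 `N#Cc1ccccc1NC(=O)N1CCC(c2nc(-c3ccc4ccccc4n3)no2)CC1`: 190 nM
Compound 2 `Cn1c(-c2noc(C3CCN(C(=O)NC4CCS(=O)(=O)CC4)CC3)n2)nc2ccccc21`: 350 nM

Of the compounds shown here, two have been measured in a functional assay on Shh Light II cells (Mus musculus) for inhibition, read by a luciferase reporter; on this read-out lower numbers stand for stronger inhibition and higher numbers for weaker inhibition. Compound 1 gives 190 nM and compound 2 gives 350 nM; these two numbers lie within the usual scatter of each other. Compound 3 `O=C(NC1CCOCC1)N1CCC(c2nc(-c3ccc4ccccc4n3)no2)CC1` is not yet measured. It differs from compound 1 in one place: oxan-4-yl in place of 2-cyanophenyl on an amide-type nitrogen. For the measured compounds named here, no measured pair shows this change directly, so the expectation rests on compound 1 alone. A modest rise in the number, close to the edge of the scatter, is expected, amounting to a 2.1-fold higher number from compound 1 to compound 3 (0.32 log units; beyond the scatter). Compound 3 is estimated at 400 nM, within a range from 120 nM to 1500 nM.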

Compound 3, half-maximal inhibitory concentration: 480 nM
Compound 3: middle estimate off by 1.2-fold (0.08 log units), on the low side; low and high end bracket the measured number.
By their numbers in this assay, from the lowest: compounds 1, 2 and 3 (each within the scatter of the next, the first and the last beyond it).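

Putting oxan-4-yl in place of 2-cyanophenyl on the amide-type nitrogen gives a 2.5-fold higher number from compound 1 to compound 3 (0.40 log units; beyond the scatter) in this assay. The step lies beyond the usual scatter but is modest, so inhibition in this series does not depend on an aromatic ring at this position. Nothing available explains the size of this step. Going by these compounds, it remains open whether the difference follows the aromatic ring, the nitrile or the ring oxygen. Phenyl or cyclohexyl on the same nitrogen would help to separate these three changes.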